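This account rests on a few compounds, and the source may have more. Where it says the series, first, only, none or still open, it means among the compounds named here.

Of the compounds shown here, three sharing one core have been tested so far in an ADME assay on L02 cells (Homo sapiens) for cytotoxicity, read by MTT assay, with a stated time of 24 h (a higher number here means a weaker inhibitor, a lower number a stronger inhibitor), and their numbers sit close together. Compound 1 (`COc1cc(/C=C2\CN(C)C/C(=C\c3cccnc3)C2=O)cc(OC)c1OC`) gives 14400 nM in this test. Compound 2 (`CN1C/C(=C\c2ccncc2)C(=O)/C(=C/c2ccc(C(F)(F)F)cc2)C1`) gives 17400 nM in the same test. Compound 3 (`Cc1ccc(S(=O)(=O)N2C/C(=C\c3cccnc3)C(=O)/C(=C/c3ccccc3F)C2)cc1`) gives 14900 nM there too. Compound 3 lies within the usual scatter of both others, so the three cannot be ranked.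

Compound 4 (`O=C1/C(=C/c2cccnc2)CN(S(=O)(=O)c2ccc(Br)cc2)C/C1=C\c1ccccc1F`) matches compound 3 except for one swap, where 4-methylphenyl becomes 4-bromophenyl in the sulfonyl group. This is bromo in place of methyl on an aromatic carbon.

Among the measured compounds shown here, no two tested compounds differ in one place only, so the data give no direct measure of this swap. Still, compound 1 at 14400 nM and compound 2 at 17400 nM have no (4-methylphenyl)sulfonyl group at all, and both remain within the scatter of compound 3. A change of one substituent on that group is therefore expected to bring no shift beyond the scatter, in either direction. The estimated 1.1-fold lower number from compound 3 to compound 4 (0.03 log units; within the scatter) is expected to stay inside that scatter. For compound 4 the estimate is 14000 nM in this assay with an expected range of 8000 nM to 25000 nM around it.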

Compound 4, half-maximal inhibitory concentration: 14600 nM
Compound 4: the middle estimate sits 1.0-fold (0.02 log units) below what was measured, within the range that was stated.
By their numbers in this assay, from the lowest: compounds 1, 4, 3 and 2 (each within the scatter of the next).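

Among the compounds shown here, compound 3 and compound 4 form the first pair in this set that differs in one place only, so the exchange of methyl for bromo can now be read directly rather than inferred from compounds that lack the sulfonyl group altogether. In this assay the pair gives a 1.0-fold lower number from compound 3 to compound 4 (0.01 log units; within the scatter) for this exchange, so on this aromatic carbon, para to a large group, the test does not tell 4-methylphenyl and 4-bromophenyl apart, at least when the rest of the molecule is that of compound 3. No measurement at hand bears on why the two substituents read alike.

Going by these compounds, this single pair covers only two substituents at one place, so it remains open whether an amine, a carboxylic acid or a longer alkyl chain at the same position would also stay within the scatter or would move the number clearly. On these data alone, it is equally open whether bromo in place of methyl would read the same way with other groups on the shared core, and, since all four compounds lie close together, which structural change could separate them in this test at all.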